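The compounds below may be only part of what the source reports. "The series", "measured", "known", "first", "only" and "open" are said of these compounds alone.

In a physicochemical assay for metabolic stability, in simulated intestinal fluid, with a stated time of 15 min, tested at 4 uM (on this read-out higher numbers stand for a more stable compound and lower numbers for a less stable compound), compound 2 (`CC[C@H](NC(=O)[C@H](COC)NC(=O)c1cc(C)on1)C(=O)N[C@@H](CC(C)C)C(=O)[C@@]1(C)CO1`) gives 100%. Compound 3 (`COC[C@H](NC(=O)c1cc(C)on1)C(=O)N[C@@H](CC#N)C(=O)N[C@@H](CC(C)C)C(=O)[C@@]1(C)CO1`) stands level with it at 100%, while compound 1 (`COC[C@H](NC(=O)c1cc(OC)no1)C(=O)N[C@@H](COC)C(=O)N[C@@H](CC(C)C)C(=O)[C@@]1(C)CO1`) gives 35%, a gap well beyond the usual scatter. The next compound, compound 4 (`COC[C@H](NC(=O)c1cc(C)on1)C(=O)N[C@@H](COC)C(=O)N[C@@H](CC(C)C)C(=O)[C@@]1(C)CO1`), departs from compound 2 by a single change: methoxy in place of methyl on a saturated chain carbon, two bonds along the chain from an amide-type nitrogen and a carbonyl carbon. In words, this is methoxy in place of methyl on a saturated chain carbon, two bonds along the chain from an amide-type nitrogen and a carbonyl carbon.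

For the measured compounds named here, only one measured step bears directly on this place, a different replacement of the same methyl by cyano: no change at the digits printed from compound 2 to compound 3 (within the scatter). That single step gives no sign of sensitivity at this place in this assay, although it says nothing about methoxy itself. The low value of compound 1 at 35% keeps a downward outcome open, so the range is wider on the lower side. The expected step is a number 8 percentage points lower from compound 2 to compound 4 (within the scatter), a slight drop at most that is not expected to exceed the scatter. Compound 4 is therefore expected at 92%, with an estimated range of 60% to 100%.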

Compound 4, percent of the compound remaining: 70%
For compound 4 the middle estimate is 22 percentage points above the measured one, within the range that was stated.
By their numbers in this assay, from the lowest: compound 1; then compound 4; then compounds 2 and 3 (each within the scatter of the next).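

In this assay, the place on a saturated chain carbon, two bonds along the chain from an amide-type nitrogen and a carbonyl carbon, proves sensitive to the group it carries: methoxy in place of methyl gives a number 30 percentage points lower from compound 2 to compound 4 (beyond the scatter), and methoxy in place of cyano gives a number 30 percentage points lower from compound 3 to compound 4 (beyond the scatter). The group on the carbonyl carbon also counts, as 5-methyl-1,2-oxazol-3-yl in place of 3-methoxy-1,2-oxazol-5-yl gives a number 35 percentage points higher from compound 1 to compound 4 (beyond the scatter). Nothing measured here accounts for either change.

On these data alone, it remains open whether an amine, a hydroxyl or a longer chain at the saturated chain carbon would follow methoxy or stay level with methyl and cyano. Also open, as far as these compounds go, is how 3-methoxy-1,2-oxazol-5-yl behaves with methyl or cyano at that carbon, since compound 1 pairs it with methoxy.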